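The source may report more compounds than this note shows. Statements on the series, on what has been measured and on what is new or still open speak of the compounds shown alone.

Two members of one series share a core carrying two aryl groups and a piperazine amide linked to a second, aryl-bearing piperazine. Compound 1 `Cc1ccc(-c2nnc(N3CCN(C(=O)CN4CCN(c5ccccc5Cl)CC4)CC3)nc2-c2ccc(C)cc2)cc1` was tested in a functional assay on MCF7 cells (Homo sapiens) for cytotoxicity, read by MTT assay, with a stated time of 24 h (a lower number here means a stronger inhibitor, a higher number a weaker inhibitor), and gave 859000 nM. Compound 2 `COc1ccc(-c2nnc(N3CCN(C(=O)CN4CCN(c5ccccc5)CC4)CC3)nc2-c2ccc(OC)cc2)cc1` was examined in the same way. In this assay compound 2 reached only the limit of the measurement, > 863000 nM, so no number is known for it. Among the two values shown, that limit is where compound 2 stands (the limit of > 863000 nM in this assay, at which 1 of the 2 values shown sits); compound 2 is therefore the one member for which only a bound, not a figure, exists.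

Compound 3 `COc1ccc(-c2nnc(N3CCN(C(=O)CN4CCN(c5cccc(Cl)c5)CC4)CC3)nc2-c2ccc(OC)cc2)cc1` has not yet been measured in this assay. It differs from compound 2 in one place: chloro in place of hydrogen on an aromatic carbon. The change puts a single chlorine onto the phenyl ring of the terminal piperazine, with no ring, donor or acceptor added. Since compound 2 sits at the limit and compound 1 lies close to the same level, the step from compound 2 to compound 3 is expected to be small, an at least 1.0-fold lower number from compound 2 to compound 3 (0.00 log units; that floor lies within the scatter), with no direction beyond the scatter. Compound 3 is accordingly estimated at 850000 nM in this assay, within a range of 400000 nM to 1800000 nM.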

Compound 3, half-maximal inhibitory concentration: > 814000 nM
Compound 3: no number, only a limit (the forecaster's own chance of this, stated with the estimate: 50%); the middle value does not contradict the limit.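

In this assay compound 3, like compound 2, gave only a limit and no figure, so the step between these two compounds cannot be read. The compounds shown leave open whether chloro in place of hydrogen on an aromatic carbon changes the measured number at all, and in which direction.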